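This account rests on a few compounds, and the source may have more. Where it says the series, first, only, none or still open, it means among the compounds named here.

Measured so far in an assay on HEK293 cells for agonist activity at transient receptor potential cation channel subfamily M member 8 (Homo sapiens), read by fluorescence and calcium flux, with a stated time of 15 min; a lower number here means that less compound is needed, a higher number that more compound is needed for the effect:
compound 1 `Cc1ccc(OCC(=O)N(Cc2cccs2)C2COC2)cc1`: 23000 nM
compound 2 `CCN(Cc1cccs1)C(=O)COc1ccc(C(C)C)cc1`: 397 nM
compound 3 `CCN(Cc1cccs1)C(=O)/C=C/c1ccc(C)cc1`: 2 nM

Within this set compound 2 stands second highest of three numbers. Its nearest neighbour is compound 1, which gives 23000 nM, a gap beyond the usual scatter; compound 3, at 2 nM, lies furthest off, also beyond the scatter. Compound 3 thus shows the lowest number of the three and compound 1 the highest, with compound 2 between them.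

Compound 4 `CCN(Cc1cccs1)C(=O)COc1ccc(C(=O)O)cc1` is not yet measured. It differs from compound 2 in one place: carboxy in place of isopropyl on an aromatic carbon. Among the compounds with values here, no measured pair isolates this change, so the expected step rests on the change itself and on how the three numbers sit. The expectation is a step to a higher number in this assay, beyond the scatter, carrying compound 4 toward the region of compound 1 rather than that of compound 3. The estimated step from compound 2 to compound 4 is a 50-fold higher number from compound 2 to compound 4 (1.70 log units; beyond the scatter). For compound 4 the expected value in this assay is 20000 nM, within a range from 3000 nM to 100000 nM; a result reported only as a limit is a real possibility.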

Compound 4, half-maximal effective concentration: "not active" (no number reported)
Nothing numeric was reported for compound 4, and the estimate cannot be compared.
By their numbers in this assay, from the lowest: compound 3; then compound 2; then compound 1.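

In this assay, within the data shown here, compound 4 is reported as not active, with no number, so no step from compound 2 to compound 4 can be read. The compounds shown leave open how other groups at this place on the aromatic ring would compare with isopropyl and carboxy. Nothing shown bears on the cause of this result.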